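Trifluoromethyl Added to a Piperidine Amide at the Assay Limit

This account rests on a few compounds, and the source may have more. Where it says the series, first, only, none or still open, it means among the compounds named here.

Compound 1 `O=C1C=CC(=O)C(c2cc(-c3ccc(C(=O)N4CCC(C(F)(F)F)CC4)s3)on2)=C1`: > 30000 nM
Compound 2 `COc1ccc(OC)c(-c2cc(-c3ccc(C(=O)N4CCCCC4)s3)on2)c1`: > 30000 nM

In a functional assay on PC-3 cells (Homo sapiens) for cytotoxicity, read by XTT assay, with a stated time of 72 h (on this read-out lower numbers stand for stronger inhibition and higher numbers for weaker inhibition), compound 1 gives > 30000 nM, a limit of the assay rather than a number. In this assay compound 2 gives > 30000 nM, again only a limit. Compound 2 therefore stands at the limit of > 30000 nM in this assay, at which 2 of the 2 values shown sit. Compound 3 `COc1ccc(OC)c(-c2cc(-c3ccc(C(=O)N4CCC(C(F)(F)F)CC4)s3)on2)c1` differs from compound 2 by trifluoromethyl in place of hydrogen on a saturated ring carbon. Compound 1 already carries the same trifluoromethyl group on a different core and still sits at that limit. The expected step is a step that the limit leaves unreadable from compound 2 to compound 3, nothing beyond the usual scatter. Compound 3 is therefore estimated at 60000 nM, within 20000 nM to 200000 nM, most likely reported once more as a limit.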

Compound 3, half-maximal inhibitory concentration: > 30000 nM
Compound 3: a limit, no number; the forecaster's own chance of this, stated with the estimate: 85%; the middle value is on the limit's open side.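

No step can be read among compound 1, compound 2 and compound 3, because each value is only a limit and all three sit at the same one: the limit of > 30000 nM in this assay, at which 3 of the 3 values shown sit.

From the compounds shown here alone, whether either structural change alters cytotoxicity at all remains open.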